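Sulfonyl aryl swap on a piperidine carboxamide series

The source may hold more compounds than are shown below. What is called first, only, known or untested is meant among the compounds shown, and "the series" means these compounds.

Measured compounds:
Compound 1 `CCN(Cc1ccccc1)C(=O)C1CCN(S(=O)(=O)c2cccc3c2OCCO3)CC1`: 53%
Compound 2 `CCN(Cc1ccccc1)C(=O)C1CCN(S(=O)(=O)c2c[nH]cn2)CC1`: "not determined" (no result reported)
Compound 3 `CCN(Cc1ccccc1)C(=O)C1CCN(S(=O)(=O)c2ccc(C(F)(F)F)nc2)CC1`: "not determined" (no result reported)

In a functional assay on CHO cells for positive allosteric modulation of muscarinic acetylcholine receptor M5 (Homo sapiens), read by calcium flux (a lower number here means a smaller maximal response, a higher number a larger maximal response), compound 1 gives 53%. In this assay compound 2 returns "not determined" (no result reported), so there is no number to place it against the rest of the series; compound 3 stands in the same position, with "not determined" (no result reported) in this assay. Only compound 1 therefore carries a maximal response that can be used.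

Compound 4 `CCN(Cc1ccccc1)C(=O)C1CCN(S(=O)(=O)c2ccc3occc3c2)CC1` is to be measured in this assay. The change from compound 2 to compound 4 is the following:

1-benzofuran-5-yl in place of 1H-imidazol-4-yl on a sulfonyl sulfur

The sulfonyl sulfur and the rest of the shared core stay as they are; only the group on the sulfonyl sulfur is exchanged. Among the compounds with values here, no step between two measured compounds is available, so the size and direction of the move in this assay on going from compound 2 to compound 4 cannot be read from the data. Compound 1, which carries a bicyclic aryl group on the same sulfonyl sulfur, gives 53% and is the only anchor in the series.

On that anchor compound 4 is expected to reach about 55% in this assay, with an estimated range from 30% to 80%.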

Compound 4, largest response reached (reported as percent of maximum), in percent of the reference or control that the assay uses: 80%
For compound 4 the middle estimate is 25 percentage points below the measured one; measured number inside the range.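

In this assay, within the data shown here, 1-benzofuran-5-yl in place of 2,3-dihydro-1,4-benzodioxin-5-yl on a sulfonyl sulfur gives a number 27 percentage points higher from compound 1 to compound 4 (beyond the scatter), the only readable step so far. The maximal response therefore depends on which group sits on the sulfonyl sulfur, even with the rest of the shared core unchanged and with a bicyclic aryl group present in both compounds, and compound 4 at 80% shows that this position can carry a group that raises the read-out beyond the scatter. Nothing at hand bears on the origin of this step.

Among these compounds, compound 2 and compound 3 carry no number, so no step to or from either can be read, and the effect of replacing 1H-imidazol-4-yl remains unknown. Also open, as far as these compounds go, is whether the higher maximal response extends to other groups on the sulfonyl sulfur, such as a plain phenyl, an indole or a quinoline, and whether a carboxylic acid or an amine on the 1-benzofuran-5-yl group would keep it.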